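The source may hold more compounds than are shown below. What is called first, only, known or untested is meant among the compounds shown, and "the series" means these compounds.

Compound 1 `CC(C)n1ncc2c(C(=O)Nc3ccc(F)cc3F)cc(-c3cccs3)nc21` — > 200000 nM
Compound 2 `CC(C)n1ncc2c(C(=O)Nc3ccncn3)cc(-c3ccsc3)nc21` — > 200000 nM
Compound 3 `CC(C)n1ncc2c(C(=O)Nc3ccc(F)cc3)cc(C3CC3)nc21` — 12500 nM

Three compounds sharing one core were tested in an ADME assay on LLC-MK2 cells (Macaca mulatta) for cytotoxicity, read by spectrophotometry and crystal violet staining, with a stated time of 4 days; on this read-out higher numbers stand for lower toxicity in this test and lower numbers for higher toxicity in this test. For compound 1 the result is only a limit of the assay, > 200000 nM, and not a number. Compound 2 likewise gives only a limit, > 200000 nM. Going by the values given here, compound 3 is the single compound with a measured number, 12500 nM. Compound 1 therefore stands at the limit of > 200000 nM in this assay, at which 2 of the 3 values shown sit, and one further value shown is also a limit rather than a number. Among the compounds with values here, no two of the measured compounds differ in only one place, so no step between them can be counted.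

Compound 4 `CC(C)n1ncc2c(C(=O)Nc3cccnc3)cc(-c3cccs3)nc21` has not yet been measured in this assay. It differs from compound 1 in a single place: pyridin-3-yl in place of 2,4-difluorophenyl on an amide-type nitrogen. Within the data shown here, with no measured step to lean on, the expectation for compound 4 rests on compound 1 sitting at the limit and on compound 3 as the one numbered value. Compound 4 is expected to stay close to that limit, with an estimate of 150000 nM and a range from 40000 nM to 300000 nM. The expected step of an at least 1.3-fold lower number from compound 1 to compound 4 (0.12 log units; that floor lies within the scatter) is thus none beyond the scatter, or at most a modest move toward higher toxicity.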

Compound 4, half-maximal cytotoxic concentration: > 200000 nM
Compound 4 gave a limit, no number (the forecaster's own chance of this, stated with the estimate: 55%); at least 1.3-fold (0.12 log units) between middle value and limit.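

Compound 1 and compound 4 both stand at a limit of the assay rather than at a number, so no step between them can be read: the limit of > 200000 nM in this assay, at which 3 of the 4 values shown sit.

The compounds shown leave open whether pyridin-3-yl in place of 2,4-difluorophenyl on an amide-type nitrogen changes the half-maximal cytotoxic concentration at all.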